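Sulfamoylurea Inhibitors: Trading Isopropylamino for an Alkoxy Group

The compounds below may be only part of what the source reports. "The series", "measured", "known", "first", "only" and "open" are said of these compounds alone.

Measured compounds:
Compound 1, `CC(C)NS(=O)(=O)NC(=O)Nc1c(C(C)C)cccc1C(C)C`: 18000 nM
Compound 2, `CCCCCCCCCCCCN(CCCCCCCCCCCC)S(=O)(=O)NC(=O)Nc1c(C(C)C)cccc1C(C)C`: 69000 nM
Compound 3, `CC(C)c1cccc(C(C)C)c1NC(=O)NS(=O)(=O)N(Cc1ccccc1)C(C)C`: 400 nM

These three compounds share one core and differ only on the sulfonyl end. In an assay on liver for inhibition of sterol O-acyltransferase 1 (Rattus norvegicus), using microsomes (on this read-out lower numbers stand for stronger inhibition and higher numbers for weaker inhibition), compound 1 gives 18000 nM and stands second highest of the three numbers; compound 2, with the two dodecyl chains, gives a higher number at 69000 nM, while compound 3 gives the lowest at 400 nM. Among the measured compounds shown here, the one step measured in one place is a 45-fold lower number from compound 1 to compound 3 (1.65 log units; beyond the scatter), a large gain.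

Compound 4, `CCCCCCC(C)OS(=O)(=O)NC(=O)Nc1c(C(C)C)cccc1C(C)C`, has not yet been measured in this assay. It differs from compound 1 by (1-methylheptyl)oxy in place of isopropylamino on a sulfonyl sulfur. For the measured compounds named here, no measured step replaces an amino group with an alkoxy group on the sulfonyl sulfur, so nothing bears on it directly. What the data offer is indirect: adding bulk on the sulfonyl end helped from compound 1 to compound 3, yet compound 2 shows that very long chains did not help. On balance a modest step toward a lower number is expected for compound 4, a 3.0-fold lower number from compound 1 to compound 4 (0.48 log units; beyond the scatter), with wide uncertainty. Compound 4 is therefore estimated at 6000 nM, in a range from 1500 nM to 25000 nM.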

Compound 4, half-maximal inhibitory concentration: 35000 nM
Beside the measured number, compound 4's estimate is 5.8-fold (0.77 log units) below it; measured number above the stated range.
By their numbers in this assay, from the lowest: compound 3; then compounds 1, 4 and 2 (each within the scatter of the next, the first and the last beyond it).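

In this assay, (1-methylheptyl)oxy in place of isopropylamino on the sulfonyl sulfur gives a 1.9-fold higher number from compound 1 to compound 4 (0.29 log units; within the scatter), so this exchange of an amino group for an alkoxy group, with its loss of the hydrogen-bond donor, shifts the number no further than repeated measurements would. The larger group entering here brings nothing like a 45-fold lower number from compound 1 to compound 3 (1.65 log units; beyond the scatter), which shows that more heavy atoms on the sulfonyl end do not by themselves bring that gain. No measurement at hand accounts for this result.

The step changes the linking atom and the chain together, and an isopropoxy group or a (1-methylheptyl)amino group on the sulfonyl sulfur would tell the two apart. Going by these compounds, whether a benzyloxy group at this place would follow compound 3 also remains open.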